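Hydroxy in Place of Fluoro: From Compound 2 to Compound 3

The source may hold more compounds than are shown below. What is called first, only, known or untested is meant among the compounds shown, and "the series" means these compounds.

Of the compounds shown here, two have so far been measured in an assay on isolated protein for inhibition of Intestinal-type alkaline phosphatase (Bos taurus), with stated times of 10 min and 30 min; on this read-out higher numbers stand for weaker inhibition and lower numbers for stronger inhibition. Compound 1 `Fc1ccc(-c2nn3c(-c4ccncc4)nnc3s2)cc1Cl` gives 2010 nM in this assay. Compound 2 `Fc1ccc(OCc2nn3c(-c4ccncc4)nnc3s2)cc1` gives 2590 nM, the higher of the two numbers, though its gap to compound 1 lies within the scatter, so no order between the two can be read from these values. Compound 3 `Oc1ccc(OCc2nn3c(-c4ccncc4)nnc3s2)cc1` has not yet been measured. It differs from compound 2 in a single place: hydroxy in place of fluoro on an aromatic carbon. For the measured compounds named here, no step between measured compounds is available to lean on, so the expectation for compound 3 rests only on the nature of the change, a hydroxy in place of a fluoro. The step is expected to be small, a 1.1-fold lower number from compound 2 to compound 3 (0.05 log units; within the scatter), in no clear direction beyond the scatter. Compound 3 is therefore estimated at 2300 nM, with a range from 900 nM to 6000 nM.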

Compound 3, half-maximal inhibitory concentration: 5610 nM
Compound 3: the middle estimate sits 2.4-fold (0.39 log units) below what was measured, and the stated range covers the measured number.
By their numbers in this assay, from the lowest: compounds 1 and 2 (each within the scatter of the next); then compound 3.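

Hydroxy in place of fluoro on an aromatic carbon, para to a large group, gives a 2.2-fold higher number from compound 2 to compound 3 (0.34 log units; beyond the scatter) in this assay, the first step that can be read between compounds differing in one place. It shows that this position is not indifferent to the group it carries: a single heavy atom exchanged there moves the number beyond the scatter, towards weaker inhibition. Nothing at hand bears on why the 4-hydroxyphenyl compound stands weaker than the 4-fluorophenyl compound.

This one step cannot tell whether any other replacement for fluoro would behave the same way, for instance a methoxy, an amine or a carboxylic acid at the same place. As far as these compounds go, whether the step would keep its size on a different linker or core also stays open.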